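The source may hold more compounds than are shown below. What is called first, only, known or untested is meant among the compounds shown, and "the series" means these compounds.

Working notes on the series.

Compound 1 `COc1ccc2c(OCc3nnc4sc(-c5cccn5C)nn34)ccnc2c1` carries a 1-methyl-1H-pyrrol-2-yl group on the shared core. For compound 1 the entry in a functional assay on EBC-1 cells (Homo sapiens) for antiproliferative activity, with a stated time of 72 h (a higher number here means a weaker inhibitor, a lower number a stronger inhibitor), reads "not determined" (no result reported), so there is no number to place it on. Within the data shown here, the two measured members sit close together: compound 2 `COc1ccc2c(OCc3nnc4sc(-c5cc[nH]c5)nn34)ccnc2c1` gives 353 nM in this assay, and compound 3 `COc1ccc2c(OCc3nnc4sc(-c5ccncc5)nn34)ccnc2c1` gives 289 nM. Among the measured compounds shown here, the one step between them, a 1.2-fold lower number from compound 2 to compound 3 (0.09 log units; within the scatter), shows that exchanging one five-membered aromatic ring for a six-membered one at this position left the number essentially unchanged.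

Compound 4 `COc1ccc(-c2nn3c(COc4ccnc5cc(OC)ccc45)nnc3s2)cc1` is obtained from compound 1 by the change (4-methoxyphenyl in place of 1-methyl-1H-pyrrol-2-yl on an aromatic carbon). For the measured compounds named here, no measured step follows this exact exchange, and compound 1 itself has no number, so the only anchor is the narrow band occupied by compound 2 and compound 3, together with the observation that the ring swap from compound 2 to compound 3 stayed within the scatter. On that basis no movement beyond the scatter is expected for compound 4 relative to the measured pair, and the range is kept wide because the link to compound 1 is unmeasured. Compound 4 is therefore estimated at 280 nM in this assay, with a range from 70 nM to 1100 nM.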

Compound 4, half-maximal inhibitory concentration: 161 nM
Compound 4: the middle estimate sits 1.7-fold (0.24 log units) above what was measured, and the stated range covers the measured number.
By their numbers in this assay, from the lowest: compounds 4, 3 and 2 (each within the scatter of the next, the first and the last beyond it).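

In this assay, among these compounds, 4-methoxyphenyl in place of 1H-pyrrol-3-yl on the aromatic carbon next to the ring nitrogen and the ring sulfur gives a 2.2-fold lower number from compound 2 to compound 4 (0.34 log units; beyond the scatter) and so provides the first modest step that passes the scatter. The exchange of pyridin-4-yl for 4-methoxyphenyl at the same carbon, which gives a 1.8-fold lower number from compound 3 to compound 4 (0.25 log units; within the scatter), cannot be told apart from no change, so the gain holds against only one of the two earlier measured groups and sets no trend across the aromatic rings tested. The compounds shown therefore establish that this position accepts a 4-methoxyphenyl ring with activity retained, but nothing available explains the step from either earlier compound.

The step from compound 1 to compound 4 cannot be read, as compound 1 has no number, which leaves the standing of 1-methyl-1H-pyrrol-2-yl against 4-methoxyphenyl unresolved. Also open, from the compounds shown here alone, is how this carbon responds to a substituent without an aromatic ring, such as an amine, a carboxylic acid or a longer alkyl chain, and whether the methoxy group of compound 4 contributes at all compared with an unsubstituted phenyl ring.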